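The source may hold more compounds than are shown below. What is called first, only, known or untested is meant among the compounds shown, and "the series" means these compounds.

In an ADME assay on cells (Homo sapiens) for cytotoxicity, read by resazurin assay, with a stated time of 5 days (a lower number here means that less compound is tolerated, a higher number that more compound is tolerated), three compounds have been read so far. Within the data shown here, compound 1 `COc1ccc(-c2nc(CC(=O)c3cccc(Cl)c3)nc3ccsc23)cn1` gives 30000 nM, the only true number in the set. Compound 2 `COc1ccc(-c2nc(C(C)(C)S(=O)(=O)c3cccc(Cl)c3)nc3ccsc23)cn1` reads > 50000 nM, which is a limit of the assay and not a number. Compound 3 `O=S(=O)(Cc1nc(-c2ccncc2)c2sccc2n1)c1cccc(Cl)c1` reads > 50000 nM, again a limit and not a number. Compound 3 therefore stands at the limit of > 50000 nM in this assay, at which 2 of the 3 values shown sit, and no exact value is known for it.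

Compound 4 `O=S(=O)(Cc1nc(-c2ccnc(Cl)c2)c2sccc2n1)c1cccc(Cl)c1` differs from compound 3 in one place: chloro in place of hydrogen on an aromatic carbon. In words, this is chloro in place of hydrogen on an aromatic carbon, next to the ring nitrogen, turning pyridin-4-yl into 2-chloropyridin-4-yl. Among the measured compounds shown here, no measured pair shows this change, so the expectation in this assay is only loosely anchored. For the measured compounds named here, the one number, for compound 1 at 30000 nM, suggests that a modest fall is the most that should be expected. The expected change is an at least 1.2-fold lower number from compound 3 to compound 4 (0.09 log units; that floor lies within the scatter), small and towards less compound tolerated. For compound 4 the estimated value is 40000 nM, with an expected range from 15000 nM to 50000 nM.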

Compound 4, half-maximal cytotoxic concentration: 63000 nM
Estimate against measurement, compound 4: 1.6-fold (0.20 log units) below; the whole stated range lies below it.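

In this assay, among these compounds, compound 3 reads > 50000 nM as a limit of the assay and not a number, so no step from compound 3 to compound 4 can be read: the limit of > 50000 nM in this assay, at which 2 of the 4 values shown sit. The compounds shown leave open how far chloro in place of hydrogen on an aromatic carbon moves the number in this assay for this pair.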